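Swapping a trifluoromethyl for a methyl on the aryl piperazine

A few compounds are considered here, and "the series" means these few. Any claim that something is new, unique, unknown or untested is made for them only; others in the source may bear on it.

Compound 1 `CC1(c2ccccc2)CC(=O)N(CC(=O)N2CCN(c3cccc(C(F)(F)F)c3)CC2)C1=O` carries a trifluoromethyl on the phenyl ring of its piperazine. In a functional assay on the whole organism (strain CD-1) with Mus musculus as the target, in the maximal electroshock model, with a stated time of 0.5 h (a lower number here means that less compound is needed, a higher number that more compound is needed for the effect), compound 1 gives 300 mg/kg, and compound 2 `CC1(c2ccccc2)CC(=O)N(CC(=O)N2CCN(c3ccccc3)CC2)C1=O`, which has hydrogen at that position, gives 300 mg/kg; these two numbers sit level, together the highest of the three measured. Compound 3 `CC1(c2ccccc2)CC(=O)N(CC(=O)N2CCN(c3ccc(F)cc3)CC2)C1=O` gives 100 mg/kg, the lowest of the set, and the steps of a 3.0-fold lower number from compound 1 to compound 3 (0.48 log units; beyond the scatter) and a 3.0-fold lower number from compound 2 to compound 3 (0.48 log units; beyond the scatter) are both beyond the scatter. The step of no change at the digits printed from compound 1 to compound 2 (within the scatter) shows that removing the trifluoromethyl altogether changed nothing within the scatter.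

Compound 4 `Cc1cccc(N2CCN(C(=O)CN3C(=O)CC(C)(c4ccccc4)C3=O)CC2)c1` differs from compound 1 by methyl in place of trifluoromethyl on an aromatic carbon. The step from compound 1 to compound 2 is the one that bears on this change, since it alters the same position of the ring, and it was flat. A methyl there is therefore expected to behave much as hydrogen did, so the expected step of no change at the digits printed from compound 1 to compound 4 (within the scatter) is none beyond the scatter. For compound 4 the estimate is 300 mg/kg, in the range 100 mg/kg to 600 mg/kg.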

Compound 4, minimum effective dose: 100 mg/kg
Compound 4: middle estimate off by 3.0-fold (0.48 log units), on the high side, and the stated range covers the measured number.
By their numbers in this assay, from the lowest: compounds 3 and 4 (each within the scatter of the next); then compounds 1 and 2 (each within the scatter of the next).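

The methyl group shows that this position does respond to what sits on it: a 3.0-fold lower number from compound 1 to compound 4 (0.48 log units; beyond the scatter) and a 3.0-fold lower number from compound 2 to compound 4 (0.48 log units; beyond the scatter) in this assay, so the earlier match between trifluoromethyl and hydrogen did not hold for every group placed there. In addition, no change at the digits printed from compound 3 to compound 4 (within the scatter), which means that 3-methylphenyl and 4-fluorophenyl, two different aryl groups on the piperazine, read alike in this test. Nothing in the data says why methyl parts from trifluoromethyl and hydrogen here.

Going by these compounds, it remains open whether this result is particular to methyl or would also appear with an ethyl, a methoxy or a chloro on the same ring carbon. The compounds shown also leave open whether a methyl and a fluoro together on one phenyl ring would read differently from either alone.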